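The source may report more compounds than this note shows. Statements on the series, on what has been measured and on what is new or still open speak of the compounds shown alone.

Of the compounds shown here, three sharing one core have been measured in an ADME assay on A549 cells (Homo sapiens) for cytotoxicity, read by resazurin assay, with a stated time of 48 h (on this read-out higher numbers stand for lower toxicity in this test and lower numbers for higher toxicity in this test), so far. Compound 1 (`CCCNc1ccc(NC(=O)c2cc(Cl)ccc2O)c(Cl)c1`) gives 22500 nM and compound 2 (`CCCN(CCC)c1ccc(NC(=O)c2cc(Cl)ccc2O)c(Cl)c1`) gives 10700 nM in this test. Compound 3 (`COc1ccc(CNc2ccc(NC(=O)c3cc(Cl)ccc3O)c(Cl)c2)cc1`) gives 80700 nM and stands highest of the three, clear of both others. Compound 4 (`O=C(Nc1ccc(NCc2cccnc2Cl)cc1Cl)c1cc(Cl)ccc1O`) has not yet been measured. It differs from compound 3 in one place: 2-chloropyridin-3-yl in place of 4-methoxyphenyl on a saturated chain carbon bound to a nitrogen on an aromatic ring. In short, 2-chloropyridin-3-yl stands in place of 4-methoxyphenyl on a saturated chain carbon bound to a nitrogen on an aromatic ring.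

The closest guide is a change at this same place, where 4-methoxyphenyl replaced ethyl: a 3.6-fold higher number from compound 1 to compound 3 (0.55 log units; beyond the scatter). The other measured step puts propyl in place of hydrogen on a nitrogen on an aromatic ring, and it bears only loosely: a 2.1-fold lower number from compound 1 to compound 2 (0.32 log units; beyond the scatter). For the measured compounds named here, both steps are modest, and no measured compound carries the new group, so the direction remains uncertain. Compound 4 keeps an aromatic ring at this place, so a modest step to a lower number in this assay is expected, leaving it above or near compound 1 at 22500 nM. That expectation amounts to a 1.8-fold lower number from compound 3 to compound 4 (0.25 log units; within the scatter). For compound 4 the estimated value is 45000 nM, with an expected range from 15000 nM to 120000 nM.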

Compound 4, half-maximal cytotoxic concentration: 101000 nM
Beside the measured number, compound 4's estimate is 2.2-fold (0.35 log units) below it; measured number inside the range.
By their numbers in this assay, from the lowest: compound 2; then compound 1; then compounds 3 and 4 (each within the scatter of the next).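

Replacing 4-methoxyphenyl with 2-chloropyridin-3-yl at this place gives a 1.3-fold higher number from compound 3 to compound 4 (0.10 log units; within the scatter) in this assay, so two aromatic groups that differ in ring atoms and substituents cannot be told apart in this test. The higher numbers seen with compound 3 are therefore not tied to 4-methoxyphenyl: the step with ethyl replaced by 2-chloropyridin-3-yl is a 4.5-fold higher number from compound 1 to compound 4 (0.65 log units; beyond the scatter), and the step with dipropylamino replaced by ((2-chloropyridin-3-yl)methyl)amino is a 9.4-fold higher number from compound 2 to compound 4 (0.97 log units; beyond the scatter). Nothing available explains why these two aromatic groups read alike or why both stand apart from the smaller groups.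

The compounds shown leave open whether an aromatic ring is needed at all, since a saturated ring such as cyclohexyl on the same chain carbon would separate the presence of a ring from its aromatic character. They also leave open whether plain phenyl, or pyridin-3-yl without the chlorine, would read like compound 3 and compound 4, or whether a substituent on the ring is needed to reach such numbers.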